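Ester in place of hexyl on a flavone-like core

The compounds below may be only part of what the source reports. "The series", "measured", "known", "first", "only" and "open" are said of these compounds alone.

Compounds measured in a functional assay on MCF7 cells (Homo sapiens) for cytotoxicity, read by neutral red uptake, with a stated time of 3 days; on this read-out higher numbers stand for weaker inhibition and lower numbers for stronger inhibition:
- Compound 1, `CCCCCCc1c(F)c(N)c2c(=O)cc(-c3ccc(N)c(F)c3)oc2c1F`, gives > 10000 nM, a limit of the assay rather than a number.
- Compound 2, `COc1c(F)c(N)c2c(=O)cc(-c3ccc(N)c(F)c3)oc2c1F`, gives 100 nM.
- Compound 3, `Nc1ccc(-c2cc(=O)c3c(N)c(F)c(Cl)c(F)c3o2)cc1F`, gives 210 nM.

Compound 1 stands only at a limit: it sits at the limit of > 10000 nM in this assay, at which 1 of the 3 values shown sits, so its true value is not known. Compound 4, `CCCCCC(=O)OCc1c(F)c(N)c2c(=O)cc(-c3ccc(N)c(F)c3)oc2c1F`, differs from compound 1 by (pentylcarbonyl)oxy in place of pentyl on a saturated chain carbon bound to an aromatic carbon. The two measured changes at the same region both removed the hexyl chain entirely and gave large improvements: an at least 100-fold lower number from compound 1 to compound 2 (2.00 log units; beyond the scatter) and an at least 47-fold lower number from compound 1 to compound 3 (1.67 log units; beyond the scatter). The change to compound 4 is different in kind, since a long chain remains and only its inner part is altered. A step beyond the scatter toward stronger inhibition in this assay is expected for compound 4, but a smaller one than those seen for compound 2 and compound 3, because an at least 100-fold lower number from compound 1 to compound 2 (2.00 log units; beyond the scatter) and an at least 47-fold lower number from compound 1 to compound 3 (1.67 log units; beyond the scatter) each followed the removal of the whole hexyl chain, whereas in compound 4 the chain is kept. Compound 4 is therefore expected to give 3000 nM, within 500 nM to 20000 nM, which is the estimated step of an at least 3.3-fold lower number from compound 1 to compound 4 (0.52 log units; beyond the scatter).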

Compound 4, half-maximal inhibitory concentration: 160 nM
For compound 4 the middle estimate is 19-fold (1.27 log units) above the measured one; the measured number lies below the stated range.
By their numbers in this assay, from the lowest: compounds 2, 4 and 3 (each within the scatter of the next, the first and the last beyond it). At a limit, above all of these: compound 1.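

In this assay compound 1 gives > 10000 nM, which is a limit of the assay and not a number. Compound 4 keeps a long chain with an ester inside it, yet the result is an at least 62-fold lower number from compound 1 to compound 4 (1.79 log units; beyond the scatter), so the hexyl chain need not be removed entirely for the number to fall, something compound 2 and compound 3, which both lack the chain, could not show. Methoxy, chloro and ((pentylcarbonyl)oxy)methyl on this aromatic carbon cannot be told apart here, with a 1.3-fold lower number from compound 3 to compound 4 (0.12 log units; within the scatter) and a 1.6-fold higher number from compound 2 to compound 4 (0.20 log units; within the scatter).

From the compounds shown here alone, it remains open whether the ester is what matters, or whether an ether or an amide link in the same chain would do the same. An acetate ester or a longer chain would show how much the chain length counts with the ester in place.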